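The compounds below may be only part of what the source reports. "The series", "measured", "known", "first", "only" and "open" are said of these compounds alone.

Measured compounds:
Compound 1 `COc1ccc(-c2cc(/C=C/C(=O)c3ccc(N)cc3)[nH]n2)cc1` — 60100 nM
Compound 2 `COc1cc(-c2cc(/C=C/C(=O)c3ccc(N)cc3)[nH]n2)cc(OC)c1OC` — > 100000 nM
Compound 3 `COc1ccc(C(=O)/C=C/c2cc(-c3cc(OC)c(OC)c(OC)c3)n[nH]2)cc1` — > 100000 nM

In a functional assay on SR cells (Homo sapiens) for inhibition, read by sulforhodamine B assay, with a stated time of 48 h (a lower number here means that less compound is tolerated, a higher number that more compound is tolerated), compound 2 gives only a limit, > 100000 nM, and no number. Compound 3, whose structure is `COc1ccc(C(=O)/C=C/c2cc(-c3cc(OC)c(OC)c(OC)c3)n[nH]2)cc1`, gives the same limit, > 100000 nM, in this assay. Compound 1 is the only one of the three with a measured number, 60100 nM in this assay; it carries fewer methoxy groups than compound 2.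

Compound 4, `COc1ccc(-c2cc(/C=C/C(=O)c3ccc(N)cc3)[nH]n2)cc1OC`, is not yet measured. It differs from compound 2 by hydrogen in place of methoxy on an aromatic carbon. Among the compounds with values here, the only step measured between compounds differing in one place is a step that the two limits leave unreadable from compound 2 to compound 3, and it concerns a different change, so it says nothing about removing a methoxy group. What remains is the limit of > 100000 nM in this assay, at which 2 of the 3 values shown sit, which leaves the position of compound 2 itself open. Compound 4 sits between compound 1 and compound 2 in its number of methoxy groups, and its value is expected to fall between their two readings, meaning a step of an at least 1.1-fold lower number from compound 2 to compound 4 (0.07 log units; that floor lies within the scatter) that cannot be judged against the scatter. Compound 4 is therefore estimated at 85000 nM, with a range from 40000 nM to 150000 nM.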

Compound 4, concentration lethal to 50% of the cells: > 100000 nM
Compound 4: only a limit was reported; the forecaster's own chance of this, stated with the estimate: 45%; middle value at least 1.1-fold (0.07 log units) from the limit.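

In this assay compound 4 gives only a limit and no number, so taking this methoxy group off compound 2 leaves the reading without a measurable value, and the step between those two limits cannot be read. Seen from the other side, a methoxy group placed on this carbon of compound 1, ortho to its existing methoxy group, gives an at least 1.6-fold higher number from compound 1 to compound 4 (0.22 log units; that floor lies within the scatter), so this single change does not by itself separate the two compounds beyond the usual scatter. Compound 4 joins the limit already shared by compound 2 and compound 3: the limit of > 100000 nM in this assay, at which 3 of the 4 values shown sit.

Going by these compounds, how far compound 4 truly lies from compound 1 remains open, since only a floor for that gap can be read. Also open, on these data alone, is whether a hydroxyl group, an ethoxy group or a fluorine atom on this carbon would give a measurable number.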